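Changing the Ester Alkyl Group in a Vitamin D Receptor Series

The compounds below may be only part of what the source reports. "The series", "measured", "known", "first", "only" and "open" are said of these compounds alone.

Compound 1, `CCN(CC)CCNC(=O)c1ccc(C(CC)(CC)c2ccc(OCC(=O)C(C)(C)C)c(C)c2)n1CC`: 91 nM in an assay on HL-60 cells for agonist activity at vitamin D3 receptor (Homo sapiens), read by microscopy, with a stated time of 96 h; a higher number here means that more compound is needed for the effect, a lower number that less compound is needed
Compound 2, `C#CC(C)OC(=O)c1ccc(C(CC)(CC)c2ccc(OCC(=O)C(C)(C)C)c(C)c2)n1CC`: 210 nM

Compound 2 holds the higher of the two numbers in this assay, its nearest neighbour being compound 1 through the modest step of a 2.3-fold higher number from compound 1 to compound 2 (0.36 log units; beyond the scatter). Compound 3, `CCn1c(C(=O)OCc2ccc(F)cc2)ccc1C(CC)(CC)c1ccc(OCC(=O)C(C)(C)C)c(C)c1`, differs from compound 2 by 4-fluorobenzyl in place of 1-methylprop-2-yn-1-yl on an oxygen next to a carbonyl group. Going by the values given here, the one measured step alters the group on the carbonyl carbon, not the group on the ester oxygen, so it bears only loosely on this change. Compound 3 is therefore expected to stay near compound 2, with a step of no change at the digits printed from compound 2 to compound 3 (within the scatter) and an estimate of 210 nM, between 80 nM and 550 nM.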

Compound 3, half-maximal effective concentration: 9500 nM
The estimate for compound 3 lay 45-fold (1.66 log units) below the measured number, outside the stated range (above it).
By their numbers in this assay, from the lowest: compound 1; then compound 2; then compound 3.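

The group on the ester oxygen turns out to matter greatly in this assay: 4-fluorobenzyl in place of 1-methylprop-2-yn-1-yl gives a 45-fold higher number from compound 2 to compound 3 (1.66 log units; beyond the scatter) and so outweighs the earlier change on the carbonyl carbon. Set against (2-(diethylamino)ethyl)amino on that carbon, (4-fluorobenzyl)oxy gives a 100-fold higher number from compound 1 to compound 3 (2.02 log units; beyond the scatter) and marks the widest gap in the series. No measured evidence accounts for the size of these steps. The compounds shown leave open whether a plain benzyl or a longer alkyl chain on the ester oxygen would stay near compound 2 or near compound 3. They also leave open whether the aromatic ring or the fluorine goes with the higher number.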